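Three Compounds at the Limit and a Longer Side Chain

The source may report more compounds than this note shows. Statements on the series, on what has been measured and on what is new or still open speak of the compounds shown alone.

Compound 3 `C=C[C@@](C)(/C=C/c1ccc(O)cc1)CC/C=C(\C)C=O` was tested in a functional assay on HepG2 cells (Homo sapiens) for cytotoxicity, with a stated time of 72 h; on this read-out lower numbers stand for an effect already at smaller amounts and higher numbers for an effect only at larger amounts of compound. In this assay compound 3 gives only a limit, > 52000 nM, and not a number. Two close relatives share its core. Compound 1 `C=C[C@@](C)(/C=C/c1ccc(O)cc1)CCC=O` gives a limit as well in this assay, > 52000 nM. Compound 2 `C=C[C@@](C)(/C=C/c1ccc(O)cc1)CC/C=C/C(=O)OCC` likewise gives only a limit in this assay, > 52000 nM. Because (the limit of > 52000 nM in this assay, at which 3 of the 3 values shown sit), none of the steps among these three compounds can be read: a step that the two limits leave unreadable from compound 1 to compound 2, a step that the two limits leave unreadable from compound 1 to compound 3 and a step that the two limits leave unreadable from compound 2 to compound 3.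

Compound 4 `C=C[C@@](C)(/C=C/c1ccc(O)cc1)CC/C=C(C)/C=C/C(=O)OCC` has not yet been measured. It differs from compound 3 as follows: 2-(ethoxycarbonyl)ethenyl in place of formyl on a double-bonded chain carbon bound to a double-bonded chain carbon and a saturated chain carbon. The nearest measured comparison is the related exchange of formyl for 2-(ethoxycarbonyl)ethenyl on a saturated chain carbon, a step that the two limits leave unreadable from compound 1 to compound 2, which the two limits leave without a readable size. So there is no measured step from which a size or a direction could be taken, and the expected step is a step that the limit leaves unreadable from compound 3 to compound 4, meaning no change that could be seen beyond the scatter. Compound 4 is therefore estimated at 80000 nM, within a range from 30000 nM to 300000 nM, and it is expected that this assay will most likely report only a limit for it.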

Compound 4, half-maximal effective concentration: > 52000 nM
Compound 4 ended at the assay's limit; the forecaster's own chance of this, stated with the estimate: 85%; the middle value does not contradict the limit.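

No size or direction can be read for the exchange between compound 3 and compound 4, because both give only a limit and not a number, as do compound 1 and compound 2: the limit of > 52000 nM in this assay, at which 4 of the 4 values shown sit.

In this assay the compounds shown leave open how far past that limit each one lies, and whether they differ from one another at all.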